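Removing the Methoxy Group: What to Expect for Compound 4

This account rests on a few compounds, and the source may have more. Where it says the series, first, only, none or still open, it means among the compounds named here.

Of the compounds shown here, three have so far been measured in an assay on cells for inhibition of Palmitoleoyl-protein carboxylesterase NOTUM variant C330S (Homo sapiens), read by fluorescence, with a stated time of 40 min; a higher number here means a weaker inhibitor, a lower number a stronger inhibitor. Compound 1 `O=C(O)C1CCN(c2ccccc2F)C1` gives 11000 nM in this assay. Compound 2 `Cc1cc(C(=O)O)c(C)n1-c1cccc(C#N)c1F` gives 630 nM. Compound 3 `COc1c(Cl)cccc1-n1c(C)cc(C(=O)O)c1C` gives 800 nM. Among these three numbers compound 3 stands second highest; its nearest neighbour is compound 2, whose number lies within the scatter of that of compound 3, while compound 1 lies much higher and well beyond the scatter.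

Compound 4 `Cc1cc(C(=O)O)c(C)n1-c1cccc(Cl)c1` has not yet been measured. It differs from compound 3 in one place: hydrogen in place of methoxy on an aromatic carbon. Among the measured compounds shown here, no step between two measured compounds carries this same change, so nothing directly shows what removing the methoxy does. The expectation therefore rests on the numbers shown: compound 2 and compound 3 share the core of compound 4 and sit close together because compound 2 gives 630 nM and compound 3 gives 800 nM, whereas compound 1, built on a different core, sits far above them. The step from compound 3 to compound 4 is expected to be a 1.5-fold higher number from compound 3 to compound 4 (0.18 log units; within the scatter), a slight rise in the number that may well stay within the scatter. Compound 4 is thus estimated to give about 1200 nM in this assay, within a range from 400 nM to 3500 nM.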

Compound 4, half-maximal inhibitory concentration: 430 nM
Compound 4: middle estimate off by 2.8-fold (0.45 log units), on the high side; measured number inside the range.
By their numbers in this assay, from the lowest: compounds 4, 2 and 3 (each within the scatter of the next); then compound 1.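

In this assay, among the compounds shown here, hydrogen in place of methoxy gives a 1.9-fold lower number from compound 3 to compound 4 (0.27 log units; within the scatter), and this is the first direct reading of any change at this position, an aromatic carbon ortho to a chloro group. It shows that the methoxy, with its 2 heavy atoms and 1 hydrogen-bond acceptor, can leave the ring without a shift that can be told apart from the usual spread of repeated measurements, so the step gives no sign that this position depends on the methoxy in this series. The data shown offer no explanation for this result.

Still open, from the compounds shown here alone, is whether other groups at this place, such as a hydroxyl, an ethoxy or an amine, would also stay within the scatter of compound 4 or would move the number clearly in either direction. Equally open, going by these compounds, is whether removing the methoxy would read the same with a methyl or a bromo group in place of the chloro group, as this single step rests on one surrounding pattern on the shared core.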